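This account rests on a few compounds, and the source may have more. Where it says the series, first, only, none or still open, it means among the compounds named here.

Measured so far in an assay on cells for inhibition of sodium/hydrogen exchanger (Oryctolagus cuniculus); on this read-out lower numbers stand for stronger inhibition and higher numbers for weaker inhibition:
compound 1 `CCC1CS(=O)(=O)c2cc(C(=O)N=C(N)N)c(C)cc21`, 24 nM
compound 2 `Cc1cc2c(cc1C(=O)N=C(N)N)S(=O)(=O)CC2`, 60 nM

For the measured compounds named here, compound 2 holds the highest of the two numbers; the only neighbour is compound 1, and the step of a 2.5-fold higher number from compound 1 to compound 2 (0.40 log units; beyond the scatter) is beyond the scatter. Compound 3 `COC1CS(=O)(=O)c2cc(C(=O)N=C(N)N)c(C)cc21` differs from compound 2 by methoxy in place of hydrogen on a saturated ring carbon. The step from compound 1 to compound 2 bears on this change, since it removed a substituent from the same saturated ring carbon and raised the number modestly. A substituent returning there is therefore expected to lower the number in this assay by a modest step, a 1.7-fold lower number from compound 2 to compound 3 (0.23 log units; within the scatter). For compound 3 the expected value is 35 nM, with a range from 12 nM to 100 nM.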

Compound 3, half-maximal inhibitory concentration: 96 nM
Compound 3: middle estimate off by 2.7-fold (0.44 log units), on the low side, within the range that was stated.
By their numbers in this assay, from the lowest: compound 1; then compounds 2 and 3 (each within the scatter of the next).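

With a 1.6-fold higher number from compound 2 to compound 3 (0.20 log units; within the scatter) methoxy stays within the scatter of hydrogen at this saturated ring carbon in this assay while a 4.0-fold higher number from compound 1 to compound 3 (0.60 log units; beyond the scatter) sets methoxy apart from ethyl. A substituent at this carbon therefore does not by itself bring the lower number seen with ethyl, and across these three compounds only ethyl stands apart from hydrogen. Nothing available explains the difference between ethyl and methoxy here.

Open, on these data alone, is whether a longer chain such as propyl, or an amine, at this carbon would track ethyl or methoxy.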